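The compounds below may be only part of what the source reports. "The series", "measured", "known", "first", "only" and "open" are said of these compounds alone.

Measured so far in an ADME assay on TZM cells (Homo sapiens) for cytotoxicity; on this read-out lower numbers stand for higher toxicity in this test and higher numbers for lower toxicity in this test:
- Compound 1 `O=[N+]([O-])c1ccc(-c2n[nH]c(O)c2CCc2cccc(Cl)c2)cc1` gives > 10000 nM, which is a limit of the assay and not a number.
- Compound 2 `NC(=S)n1nc(-c2ccc([N+](=O)[O-])cc2)c(Cc2cccc(Cl)c2)c1O` gives > 10000 nM, again a limit rather than a number.

Compound 2 therefore stands at the limit of this assay, and it does not stand there alone: the limit of > 10000 nM in this assay, at which 2 of the 2 values shown sit. Going by the values given here, no step between measured compounds can be drawn from two limits, so nothing is known about how any change moves this read-out.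

Compound 3 `O=[N+]([O-])c1ccc(-c2n[nH]c(O)c2Cc2cccc(Cl)c2)cc1` is still to be measured in this assay. It differs from compound 2 by a hydrogen atom in place of a group of 3 heavy atoms (1 carbon, 1 nitrogen, 1 sulfur; no ring), on an aromatic nitrogen. Compound 1, which carries a hydrogen on that nitrogen, also sits at the limit, so no step beyond the usual scatter is expected from compound 2 to compound 3 in this assay, and the estimated step is a step that the limit leaves unreadable from compound 2 to compound 3. Compound 3 is expected to give about 20000 nM, within 8000 nM to 60000 nM, most likely reported again only as a limit.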

Compound 3, half-maximal cytotoxic concentration: > 10000 nM
Compound 3 gave a limit, no number (the forecaster's own chance of this, stated with the estimate: 80%); the middle value lies beyond the limit too.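

No step can be read among compound 1, compound 2 and compound 3 in this assay, since each gives only a limit of the assay and not a number: the limit of > 10000 nM in this assay, at which 3 of the 3 values shown sit.

The compounds shown leave open whether any of these changes moves this read-out, and by how much.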